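Replacing the bromophenyl arm with a short hydroxyethyl chain

The source may report more compounds than this note shows. Statements on the series, on what has been measured and on what is new or still open speak of the compounds shown alone.

This set of compounds shares one core and differs only in the group carried on the five-membered ring with three nitrogens. Compound 1 `O=C1O[C@H]([C@@H](O)Cn2cc(-c3ccc(Br)cc3)nn2)C(OCc2ccccc2)=C1OCc1ccccc1` bears a 4-bromophenyl group there; in a functional assay on HCT-116 cells (Homo sapiens) for antiproliferative activity, read by MTT assay, with a stated time of 72 h (on this read-out lower numbers stand for stronger inhibition and higher numbers for weaker inhibition), compound 1 gives 9420 nM, the lowest number of the three measured compounds, so it is the most potent of them. Compound 2 `CC(C)(C)c1cn(C[C@H](O)[C@H]2OC(=O)C(OCc3ccccc3)=C2OCc2ccccc2)nn1` carries a tert-butyl group instead and gives 28300 nM, a shift of a 3.0-fold higher number from compound 1 to compound 2 (0.48 log units; beyond the scatter). Compound 3 `O=C1O[C@H]([C@@H](O)Cn2cc(C3CC3)nn2)C(OCc2ccccc2)=C1OCc1ccccc1` carries a cyclopropyl group and gives 30400 nM, a shift of a 3.2-fold higher number from compound 1 to compound 3 (0.51 log units; beyond the scatter). Between compound 2 and compound 3 the change is a 1.1-fold higher number from compound 2 to compound 3 (0.03 log units; within the scatter), so the two replacement groups cannot be told apart on these numbers.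

Compound 4 `O=C1O[C@H]([C@@H](O)Cn2cc(CCO)nn2)C(OCc2ccccc2)=C1OCc1ccccc1` has not yet been measured. Its change from compound 1 is 2-hydroxyethyl in place of 4-bromophenyl on an aromatic carbon. Both measured steps that swap out the 4-bromophenyl group weakened activity by a modest, similar amount, and nothing here suggests that a 2-hydroxyethyl group would behave differently. A loss of about the same size, or somewhat larger, is therefore expected, giving an estimated step of a 3.7-fold higher number from compound 1 to compound 4 (0.57 log units; beyond the scatter). Compound 4 is estimated at 35000 nM, with a likely range of 15000 nM to 85000 nM.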

Compound 4, half-maximal inhibitory concentration: 72700 nM
Beside the measured number, compound 4's estimate is 2.1-fold (0.32 log units) below it; the measured number falls inside the stated range.
By their numbers in this assay, from the lowest: compound 1; then compounds 2 and 3 (each within the scatter of the next); then compound 4.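

In this assay, the 2-hydroxyethyl group brings the largest loss yet seen at this position, with a 7.7-fold higher number from compound 1 to compound 4 (0.89 log units; beyond the scatter) set against the smaller steps for tert-butyl and cyclopropyl. It also shows that the replacement groups are not interchangeable, since tert-butyl and cyclopropyl could not be told apart, whereas the 2-hydroxyethyl compound stands clear of both, with a 2.4-fold higher number from compound 3 to compound 4 (0.38 log units; beyond the scatter) and with a 2.6-fold higher number from compound 2 to compound 4 (0.41 log units; beyond the scatter) as well, so removing the 4-bromophenyl group does not set a single level of activity and the entering group also counts. The 2-hydroxyethyl group is the only one of the four that carries oxygen, but no accompanying measurement explains the weaker result.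

The compounds shown cannot separate the effect of the hydroxyl from that of the two-carbon chain, and a plain ethyl or a 2-methoxyethyl group would test that directly. Also open, from the compounds shown here alone, are how an amine or a carboxylic acid at the end of the chain, or a longer hydroxyalkyl chain, would read, and whether a plain phenyl group would keep the activity of compound 1 without the bromine.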